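Trimming an Aryl Ether Down to Isopropyl

The compounds below may be only part of what the source reports. "The series", "measured", "known", "first", "only" and "open" are said of these compounds alone.

Compound 1, `Clc1ccncc1C1=CC2CNCC(C1)C2`, gives 128 nM in an in vitro assay on SH-SY5Y cells for displacement of a labelled ligand from Neuronal acetylcholine receptor; alpha3/beta4 (Homo sapiens); a lower number here means a stronger inhibitor, a higher number a weaker inhibitor
Compound 2, `COc1ccccc1Oc1cncc(C2=CC3CNCC(C2)C3)c1`, gives 56 nM in this assay
Compound 3, `C1=C(c2ccncc2)CC2CNCC1C2`, gives 459 nM in this assay

All three compounds share the same bicyclic amine core and differ only in what is attached to the pyridine ring. Compound 2 has the lowest number of the three in this assay, and both other compounds sit beyond the usual scatter above it: compound 1 is the nearer of the two, and compound 3, which carries no substituent on the pyridine at all, is the furthest away. On these numbers alone, putting a substituent on the pyridine goes with a lower number, and the large aryl ether of compound 2 goes with the lowest.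

Compound 4, `CC(C)Oc1cncc(C2=CC3CNCC(C2)C3)c1`, keeps the ether oxygen of compound 2 but changes what hangs from it: isopropyl in place of 2-methoxyphenyl on an oxygen on an aromatic ring. Going by the values given here, no measured pair shows this kind of exchange, so the size of the step is uncertain. Among the compounds with values here, since the only compound with a small substituent, compound 1, gives 128 nM, a modest rise in the number is expected for compound 4, beyond the scatter but well short of the level of compound 3. The step from compound 2 to compound 4 is expected to be a 2.3-fold higher number from compound 2 to compound 4 (0.37 log units; beyond the scatter). Compound 4 is estimated at 130 nM, with a likely range from 45 nM to 380 nM.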

Compound 4, inhibition constant: 4.8 nM
Compound 4: middle estimate off by 27-fold (1.43 log units), on the high side; measured number outside the range, below it.
By their numbers in this assay, from the lowest: compound 4; then compound 2; then compound 1; then compound 3.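

Putting isopropyl in place of 2-methoxyphenyl on the oxygen gives a 12-fold lower number from compound 2 to compound 4 (1.07 log units; beyond the scatter) in this assay, so the aromatic ring and its methoxy group are not needed for a low number at this place. The earlier compounds shown here left the large aryl ether with the lowest number, but this direct pair, which differs in only one place, shows that a branched group of 3 carbon atoms on the same oxygen can do far better than the 8-atom group it replaces. Nothing measured here explains why the smaller group goes with the lower number.

This single exchange changes several things at once, so it leaves open whether the gain comes from losing the ring, losing the methoxy group, or gaining the branched shape, and an unsubstituted phenyl on the oxygen would help to separate these. Also open, from the compounds shown here alone, is how far the trend runs in either direction, for instance with methyl or a longer butyl chain on the oxygen, and whether the oxygen itself matters, which an amine nitrogen or a plain carbon link in its place would test.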